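Changing the Halogenated Phenyl Group and Cell Growth Inhibition

This account rests on a few compounds, and the source may have more. Where it says the series, first, only, none or still open, it means among the compounds named here.

Of the compounds shown here, two have so far been tested in a functional assay on HL-60 cells (Homo sapiens) for antiproliferative activity, read by MTT assay, with a stated time of 72 h; a higher number here means a weaker inhibitor, a lower number a stronger inhibitor. Compound 1 `NC1=NC2(CCOCC2)N(OCCCOc2ccc(F)cc2)C(N)=N1` gives 2380 nM in this assay. Compound 2 `NC1=NC2(CCSCC2)N(OCCCOc2cccc(Cl)c2Cl)C(N)=N1` gives 30 nM in this assay, the lowest number of the two, and its gap to compound 1 lies far beyond the usual scatter of repeated measurements. Compound 3 `NC1=NC2(CCSCC2)N(OCCCOc2ccccc2Br)C(N)=N1` has not yet been measured. It differs from compound 2 in a single place: 2-bromophenyl in place of 2,3-dichlorophenyl on an oxygen on a saturated carbon. Among the measured compounds shown here, no measured pair shows what this exchange does, so the expectation rests on compound 2 alone. Because compound 2 gives 30 nM in this assay, the step of a 2.7-fold higher number from compound 2 to compound 3 (0.43 log units; beyond the scatter) is expected to be a modest rise in the number, at the edge of the scatter or a little beyond it. Compound 3 is therefore estimated to give 80 nM, with a likely range from 25 nM to 250 nM.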

Compound 3, half-maximal inhibitory concentration: 180 nM
Compound 3: middle estimate off by 2.3-fold (0.35 log units), on the low side; the range from low to high includes it.
By their numbers in this assay, from the lowest: compound 2; then compound 3; then compound 1.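

In this assay, among the compounds shown here, replacing 2,3-dichlorophenyl with 2-bromophenyl while the rest of the molecule stays the same gives a 6.0-fold higher number from compound 2 to compound 3 (0.78 log units; beyond the scatter), the first direct reading of a change at this place on the shared core. The exchange alters both the kind and the number of halogens on the phenyl ring, as two chlorines leave and one bromine enters, so this single step cannot show how much each part contributes. Nothing available explains why the number rises.

The compounds shown leave open whether 2-chlorophenyl, with one chlorine and no bromine, would sit closer to compound 2 or to compound 3. They also leave open how an unsubstituted phenyl, or a phenyl carrying an amine, would behave at this place.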